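Trimming the Ring Group on a Fused Core

A few compounds are considered here, and "the series" means these few. Any claim that something is new, unique, unknown or untested is made for them only; others in the source may bear on it.

In a physicochemical assay for solubility, read by LC-MS, in phosphate buffer, with a stated time of 24 h, at pH 7.4 (on this read-out lower numbers stand for lower solubility and higher numbers for higher solubility), compound 1 `O=C1c2ccccc2CN1c1cnc(NCc2c(F)ccc3c2CCO3)n2cnnc12` gives 4000 nM, the lowest of the two numbers reported here. For the measured compounds named here, compound 3 `CN(C)Cc1ccc2c(c1)CN(c1cnc(NCc3c(F)ccc4c3CCO4)n3cnnc13)C2=O` gives 12000 nM, and the step of a 3.0-fold higher number from compound 1 to compound 3 (0.48 log units; beyond the scatter) is the only measured step that changes a single place. Compound 2 `CC(=O)N1CCC(c2cnc(NCc3c(F)ccc4c3CCO4)c3cn[nH]c(=O)c23)CC1` gives only < 2000 nM, which is a limit of the assay rather than a number (the limit of < 2000 nM in this assay, at which 1 of the 3 values shown sits). Compound 4 `O=C1CCCN1c1cnc(NCc2c(F)ccc3c2CCO3)n2cnnc12` differs from compound 1 by a group of 6 heavy atoms (4 carbon, 1 nitrogen, 1 oxygen; one five-membered non-aromatic ring with 1 hetero atom) in place of a group of 10 heavy atoms (8 carbon, 1 nitrogen, 1 oxygen; one five-membered non-aromatic ring with 1 hetero atom, one six-membered aromatic ring of carbon only), on an aromatic carbon. Going by the values given here, no measured step covers this change; the step from compound 1 to compound 3 concerns another group at another place and gives no direct guide. The change is therefore expected to shift solubility only modestly, if at all, a 2.0-fold higher number from compound 1 to compound 4 (0.30 log units; within the scatter). Compound 4 is estimated at 8000 nM, within 3000 nM to 20000 nM.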

Compound 4, solubility: 640000 nM
Compound 4: middle estimate off by 80-fold (1.90 log units), on the low side; the measured number lies above the stated range.
By their numbers in this assay, from the lowest: compound 1; then compound 3; then compound 4. At a limit, below all of these: compound 2.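

In this assay, putting 2-oxopyrrolidin-1-yl on this aromatic carbon gives a 160-fold higher number from compound 1 to compound 4 (2.20 log units; beyond the scatter) and so far exceeds the other step from the same parent, a 3.0-fold higher number from compound 1 to compound 3 (0.48 log units; beyond the scatter), in size. Exchanging the whole group at this place therefore moves the number much further than adding (dimethylamino)methyl to that group, though the leaving and entering groups carry the same counts of hydrogen-bond donors and acceptors. Nothing measured here explains the size of this step.

The compounds shown leave open whether an open-chain acetamido group or a morpholine at this place would give a similar number. They also leave open whether (dimethylamino)methyl would change the number of compound 4 at all.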